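Notes on a triazole series: benzoyloxy to propyl

The source may report more compounds than this note shows. Statements on the series, on what has been measured and on what is new or still open speak of the compounds shown alone.

Two compounds have numbers in an assay on nucleic acid for inhibition of Nucleic Acid, read by fluorescence, tested at 100 uM; on this read-out lower numbers stand for less inhibition and higher numbers for more inhibition at the one concentration tested (going by the name of the read-out). Compound 1 `O=C(OCC(O)Cn1cc(CN2CCN(c3ccccc3)CC2)nn1)c1ccccc1` gives 11% in this assay. Compound 2 `CCOC(=O)C1CCCN(Cc2cn(C3CCCCC3O)nn2)C1` gives 16% in this assay. These two numbers lie within the scatter of each other, so neither can be set apart from the other; both sit at the low end of the read-out. For the measured compounds named here, no pair of measured compounds differs in a single place, so no step size has yet been seen. Compound 3 `CCCCC(O)Cn1cc(CN2CCN(c3ccccc3)CC2)nn1` has not been measured. It differs from compound 1 by propyl in place of benzoyloxy on a saturated chain carbon, two bonds along the chain from an oxygen on a saturated carbon. Going by the values given here, with no measured step to compare against and both measured numbers low, the change is expected to stay within the scatter, in either direction, a number 1 percentage points higher from compound 1 to compound 3 (within the scatter) being the estimated step. Compound 3 is expected to give 12% in this assay, with a range from 0% to 30%.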

Compound 3, a percentage reported as inhibition, at one concentration (the size of the read-out at that concentration, not a potency): 47%
The estimate for compound 3 lay 35 percentage points below the measured number; measured number outside the range, above it.
By their numbers in this assay, from the lowest: compounds 1 and 2 (each within the scatter of the next); then compound 3.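

Propyl in place of benzoyloxy on a saturated chain carbon, two bonds along the chain from an oxygen on a saturated carbon, gives a number 36 percentage points higher from compound 1 to compound 3 (beyond the scatter) in this assay and is the first single-place step seen in this series. This place can therefore move the read-out beyond the scatter, and a group with no ring and no hydrogen-bond acceptors is enough for that here. Nothing measured accounts for the step.

The compounds shown leave open whether the step follows from the loss of benzoyloxy, the arrival of propyl, or both. From the compounds shown here alone, how the read-out responds at this place to an amine, a carboxylic acid or a chain longer than propyl also remains open.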